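A few compounds are considered here, and "the series" means these few. Any claim that something is new, unique, unknown or untested is made for them only; others in the source may bear on it.

Measured compounds:
compound 1 `O=C(O)CCCOc1ccc(-c2cc(Oc3cccc(F)c3)ccc2Cl)cc1`, 3350 nM
compound 2 `Cc1cc(OCCCC(=O)O)ccc1-c1cc(OC(F)(F)F)ccc1Cl`, a limit: > 9950 nM
compound 3 `Cc1cc(OC2CCC2)cc(-c2ccc3oc(CCC(=O)O)cc3c2)c1`, 2960 nM

Of the compounds shown here, three have been tested in a functional assay on isolated protein for agonist activity at Free fatty acid receptor 1 (Homo sapiens), read by HTRF and inositol phosphate accumulation, with a stated time of 60 min; on this read-out higher numbers stand for an effect only at larger amounts of compound and lower numbers for an effect already at smaller amounts. Compound 1 and compound 3 give numbers that sit within the scatter of each other, so nothing separates them. For compound 2 the assay reports only a limit, (the limit of > 9950 nM in this assay, at which 1 of the 3 values shown sits), and no number. Compound 3 therefore stands with compound 1 among the measured numbers, with compound 2 unresolved.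

Compound 4 `O=C(O)CCc1cc2cc(-c3cc(Cl)cc(OC4CCC4)c3)ccc2o1` differs from compound 3 in one place: chloro in place of methyl on an aromatic carbon. Among the compounds with values here, no measured pair shows the effect of this exchange. The step from compound 3 to compound 4 is expected to stay within the scatter, a 1.2-fold lower number from compound 3 to compound 4 (0.07 log units; within the scatter). Compound 4 is estimated at 2500 nM, with a range from 800 nM to 8000 nM.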

Compound 4, half-maximal effective concentration: > 9950 nM
Compound 4 ended at the assay's limit; the forecaster's own chance of this, stated with the estimate: 15%; at least 3.9-fold (0.59 log units) between middle value and limit.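

In this assay, replacing methyl with chloro on this aromatic carbon, meta to a cyclobutyloxy group, is not a silent change: an at least 3.3-fold higher number from compound 3 to compound 4 (0.52 log units; beyond the scatter). The earlier compounds shown here, with no step between them, could not show that this position responds to the exchange of a single heavy atom. Compound 4 gives only a limit, not a number: the limit of > 9950 nM in this assay, at which 2 of the 4 values shown sit.

Going by these compounds, the full size of the step therefore stays open. The compounds shown also leave open whether fluoro, methoxy or plain hydrogen on this carbon would sit closer to methyl or to chloro.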